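The source may hold more compounds than are shown below. What is called first, only, known or untested is meant among the compounds shown, and "the series" means these compounds.

Measured so far:
compound 1 `NC(=S)Nc1cccc(OCCCCCc2ccccc2)c1` — in an ADME assay on Ava5 cells (Homo sapiens) for cytotoxicity (a lower number here means that less compound is tolerated, a higher number that more compound is tolerated), compound 1 gives 22000 nM
compound 2 `CC(CCOc1ccccc1)CCOc1cccc(NC(N)=S)c1` — compound 2 gives only a limit of the assay, > 50000 nM
compound 3 `NC(=S)Nc1cccc(OCCCCCOc2ccc(F)cc2)c1` — compound 3 gives 5000 nM

Compound 3 stands lowest of the two numbers; its nearest neighbour is compound 1, as seen in the step of a 4.4-fold lower number from compound 1 to compound 3 (0.64 log units; beyond the scatter), where a 4-fluorophenoxy took the place of phenyl at the chain end. Compound 4 `CCN(CC)c1ccc(OCCCCCOc2cccc(NC(N)=S)c2)cc1` differs from compound 3 by diethylamino in place of fluoro on an aromatic carbon. For the measured compounds named here, only the step of a 4.4-fold lower number from compound 1 to compound 3 (0.64 log units; beyond the scatter) bears on this end of the molecule, and it was modest; the present change touches only a substituent of that same terminal ring. In this assay compound 4 is therefore expected to move little, a 1.3-fold lower number from compound 3 to compound 4 (0.10 log units; within the scatter), and its estimated value is 4000 nM, within 1500 nM to 12000 nM.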

Compound 4, half-maximal cytotoxic concentration: > 50000 nM
Compound 4 gave a limit, no number; the forecaster's own chance of this, stated with the estimate: 5%; middle value at least 12-fold (1.09 log units) away from the limit.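

In this assay, a change confined to this aromatic carbon, para to a large group, is enough to move the value beyond the scatter, and upward: diethylamino in place of fluoro gives an at least 10-fold higher number from compound 3 to compound 4 (1.00 log units; beyond the scatter). Compound 4 gives > 50000 nM, which is a limit of the assay and not a number. The step is therefore only a lower bound, and this limit is not unique to compound 4: the limit of > 50000 nM in this assay, at which 2 of the 4 values shown sit.

Going by these compounds, whether the shift belongs to diethylamino alone remains open. Dimethylamino, methoxy or a carboxylic acid on the same aromatic carbon would test this.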